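The compounds below may be only part of what the source reports. "The series", "measured", "known", "first", "only" and "open" are said of these compounds alone.

Measured so far, all in an assay on isolated protein with Bile acid receptor (Homo sapiens) as the target; a higher number here means that more compound is needed for the effect, a lower number that less compound is needed:

compound 1, `COC(=O)/C=C/c1cccc(N(Cc2ccc(/C=C/c3c(C)cc(C)cc3C)cc2)C(=O)C(C)C)c1`, with 149 nM
compound 2, `COC(=O)/C=C/c1cccc(N(Cc2ccc(/C=C/c3c(C)cc(C)cc3C)cc2)C(=O)NC(C)C)c1`, with 431 nM
compound 3, `COC(=O)/C=C/c1cccc(N(Cc2ccc(-c3c(OC)cccc3OC)cc2)C(=O)C2CCCCC2)c1`, with 77 nM

Compound 1 stands second highest of these three numbers. Its nearest neighbour is compound 3, whose number is lower but within the scatter of the method, so the two cannot be told apart. Among the compounds with values here, the only step with a single change runs a 2.9-fold higher number from compound 1 to compound 2 (0.46 log units; beyond the scatter), where isopropylamino replaces isopropyl on the carbonyl carbon; that step lies beyond the scatter and is modest in size.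

The unmeasured compound 4, `COC(=O)/C=C/c1cccc(N(Cc2ccc(-c3ccc(N(C)C)cc3)cc2)C(=O)C(C)C)c1`, differs from compound 1 elsewhere: 4-(dimethylamino)phenyl in place of 2-(2,4,6-trimethylphenyl)ethenyl on an aromatic carbon. Within the data shown here, no measured step touches this part of the molecule, so the one step known, from compound 1 to compound 2, does not bear on it directly. Compound 3 also carries a directly attached aryl group here, but it differs from compound 1 in a second place as well, so only its value can be noted. Because compound 3 shows 77 nM, an aryl group in this position is compatible with a number close to that of compound 1. The expectation for compound 4 is therefore a modest rise, a 2.0-fold higher number from compound 1 to compound 4 (0.30 log units; within the scatter), with wide uncertainty. The estimated value for compound 4 is 300 nM, expected to fall between 80 nM and 1200 nM.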

Compound 4, half-maximal effective concentration: 57 nM
Compound 4: the middle estimate sits 5.3-fold (0.72 log units) above what was measured; measured number below the stated range.
By their numbers in this assay, from the lowest: compounds 4, 3 and 1 (each within the scatter of the next, the first and the last beyond it); then compound 2.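

The aromatic carbon para to a large group tolerates a complete exchange of its substituent: in this assay, 4-(dimethylamino)phenyl in place of 2-(2,4,6-trimethylphenyl)ethenyl gives a 2.6-fold lower number from compound 1 to compound 4 (0.42 log units; beyond the scatter). Less compound is therefore needed after the exchange, so neither the double bond outside the aromatic rings nor the trimethyl-substituted ring is required for a number at this level, at least with the isopropyl carbonyl kept in place. Nothing available explains why this exchange lowers the number.

This single exchange changes the linker, the ring substituents and the nitrogen content at once, so the part responsible cannot be identified. From the compounds shown here alone, it remains open how an unsubstituted phenyl at this position would compare, or a 4-aminophenyl carrying a primary amine instead of the dimethylamino group.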